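The source may report more compounds than this note shows. Statements on the series, on what has been measured and on what is new or still open speak of the compounds shown alone.

Compound 1 `O=C(Nc1ccc(Nc2ncnc3c2OCCN3)cc1)Nc1ccc(Cl)c(C(F)(F)F)c1`, compound 2 `O=C(Nc1ccc(Br)cc1)Nc1ccc(Nc2ncnc3c2OCCN3)cc1` and compound 3 `O=C(Nc1ccc(Nc2ncnc3c2OCCN3)cc1)Nc1ccc(C(F)(F)F)cc1` share one core and differ only in the aryl group on one urea nitrogen. In an assay on isolated protein for inhibition of proto-oncogene tyrosine-protein kinase receptor Ret variant V804L (Homo sapiens), read by 33P incorporation, with stated times of 15 min and 40 min (on this read-out higher numbers stand for weaker inhibition and lower numbers for stronger inhibition), compound 1 gives 285 nM. In this assay compound 2 reaches only the limit > 10000 nM, so no number is known for it. In this assay compound 3 gives 2470 nM, the higher of the two numbers that were obtained, with compound 1 below it. Among the compounds with values here, the one step that can be measured here, an at least 4.0-fold lower number from compound 2 to compound 3 (0.60 log units; beyond the scatter), shows that the trifluoromethyl group lowered the number noticeably compared with bromo.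

Compound 4 `Cc1ccc(F)c(NC(=O)Nc2ccc(Nc3ncnc4c3OCCN4)cc2)c1` is reached from compound 3 by the change (2-fluoro-5-methylphenyl in place of 4-(trifluoromethyl)phenyl on an amide-type nitrogen). That removes the very group that helped in the step from compound 2 to compound 3, and compound 1 gives its lower value only with chloro beside trifluoromethyl present. Compound 4 is therefore expected to show a weaker result, with a step of a 2.4-fold higher number from compound 3 to compound 4 (0.39 log units; beyond the scatter) towards higher numbers. Compound 4 is estimated at 6000 nM, within 1500 nM to 20000 nM.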

Compound 4, half-maximal inhibitory concentration: 7000 nM
For compound 4 the middle estimate is 1.2-fold (0.07 log units) below the measured one; the range from low to high includes it.
By their numbers in this assay, from the lowest: compound 1; then compound 3; then compound 4. At a limit, above all of these: compound 2.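

Putting 2-fluoro-5-methylphenyl in place of 4-(trifluoromethyl)phenyl on an amide-type nitrogen gives a 2.8-fold higher number from compound 3 to compound 4 (0.45 log units; beyond the scatter) in this assay, so among the compounds with a measured number, the one without trifluoromethyl has the highest. Against the bromo compound the reading is an at least 1.4-fold lower number from compound 2 to compound 4 (0.15 log units; that floor lies within the scatter), so compound 4 and compound 2 cannot be put in order. Compound 2 itself stands only at a limit of the assay: the limit of > 10000 nM in this assay, at which 1 of the 4 values shown sits.

Compound 4 brings a fluoro and a methyl group in one change, so the step cannot be divided between these two groups. Also open, going by these compounds, is how this assay would read with a phenyl ring carrying a nitrile, an amine or a carboxylic acid on this nitrogen.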